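This account rests on a few compounds, and the source may have more. Where it says the series, first, only, none or still open, it means among the compounds named here.

Three members of the series have been run in a functional assay on NB-4 cells (Homo sapiens) for inhibition, read by XTT assay, with a stated time of 48 h; on this read-out lower numbers stand for stronger inhibition and higher numbers for weaker inhibition. Compound 1 `COc1ccc(C(=O)/C(=C/C2CCCCC2)COC(C)=O)cc1` gives 23300 nM. Compound 2 `C/C=C(\COC(=O)c1ccccc1)C(=O)c1ccc(OC)cc1` gives 16200 nM. Compound 3 `COc1ccc(C(=O)/C(=C/c2ccc(Cl)cc2Cl)CCOC(C)=O)cc1` gives 34800 nM, the highest of the three numbers: its nearest neighbour is compound 1, whose number is lower by an amount within the scatter of this assay, and its furthest is compound 2, whose number is lower by an amount beyond the scatter. Within the data shown here, no two of these three compounds differ in a single place, so no step between measured compounds can be drawn from them.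

Compound 4 `COc1ccc(C(=O)/C(=C/c2ccccc2Cl)CCOC(C)=O)cc1` is yet to be measured. It differs from compound 3 in one place: hydrogen in place of chloro on an aromatic carbon. Among the measured compounds shown here, nothing among the measured compounds shows what removing a single chloro from this ring does, so no direction is established. Since the three measured numbers sit in a narrow band, the expected step in this assay is none beyond the scatter. In this assay compound 4 is expected to give 30000 nM, with a range from 12000 nM to 75000 nM. The step this estimate implies, a 1.2-fold lower number from compound 3 to compound 4 (0.06 log units; within the scatter), is expected to stay within the scatter.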

Compound 4, half-maximal inhibitory concentration: 51600 nM
Beside the measured number, compound 4's estimate is 1.7-fold (0.24 log units) below it; low and high end bracket the measured number.
By their numbers in this assay, from the lowest: compounds 2, 1, 3 and 4 (each within the scatter of the next, the first and the last beyond it).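

In this assay the series now has its first step between compounds that differ in one place: a 1.5-fold higher number from compound 3 to compound 4 (0.17 log units; within the scatter). Going from 2,4-dichlorophenyl to 2-chlorophenyl, with hydrogen in place of the chloro on the aromatic carbon para to a large group, therefore does not separate the two compounds on this read-out, so this chloro is not shown to matter here. This is a single pair and sets no pattern for the series, and nothing at hand gives a reason for the outcome or a measured property of either group.

Open, from the compounds shown here alone, is whether a different group on this same aromatic carbon, such as methoxy, an amine or a carboxylic acid, would give a step beyond the scatter, and whether the remaining chloro of the 2-chlorophenyl group matters any more than the one exchanged here. Also open, going by these compounds, is whether the same exchange of chloro for hydrogen reads alike when the ester chain of the shared core is replaced by a longer chain or an amide.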